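The source may hold more compounds than are shown below. What is called first, only, known or untested is meant among the compounds shown, and "the series" means these compounds.

Compound 3 `Nc1ccccc1NC(=O)c1ccc(Cn2cnc3c(Nc4ccc(-c5ccccn5)cc4)nc(Cl)nc32)cc1` was tested in a functional assay on NCI-H460 cells (Homo sapiens) for antiproliferative activity, read by CCK-8 assay, with a stated time of 72 h, tested at 2 uM (a lower number here means a weaker effect, a higher number a stronger effect of the compound at the concentration tested), where compound 3 gives 18.1%. Among the three measured compounds this places compound 3 second highest. Compound 1 `Nc1ccccc1NC(=O)c1ccc(Cn2cnc3c(Nc4ccccc4)nc(Cl)nc32)cc1` stands furthest from it; in this assay compound 1 gives 42.7%. Compound 2 `Nc1ccccc1NC(=O)/C=C/c1ccc(Cn2cnc3c(NCc4ccccc4)nc(Cl)nc32)cc1` stands nearest; in this assay compound 2 gives 4.62%. Within the data shown here, the only single-point step among the measured compounds runs from compound 1 to compound 3, pyridin-2-yl in place of hydrogen on an aromatic carbon, and it was a number 24.6 percentage points lower from compound 1 to compound 3 (beyond the scatter).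

Compound 4 `Nc1ccccc1NC(=O)c1ccc(Cn2cnc3c(NCc4ccccc4)nc(Cl)nc32)cc1` remains to be measured. It differs from compound 3 as follows: benzyl in place of 4-(pyridin-2-yl)phenyl on a nitrogen on an aromatic ring. Among the measured compounds shown here, the group that leaves carries the pyridin-2-yl whose introduction lowered the number between compound 1 and compound 3, while the benzyl that enters is also present in compound 2, which gives 4.62%, though compound 2 differs from compound 4 in its linker as well, so no clean step between them exists. The step is therefore expected to be small, estimated at a number 3.1 percentage points lower from compound 3 to compound 4 (within the scatter). Compound 4 is expected to give 15%, within a range from 2% to 35%.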

Compound 4, a percentage reported as inhibition, at one concentration (the size of the read-out at that concentration, not a potency): 44.7%
The estimate for compound 4 lay 29.7 percentage points below the measured number, and the stated range ends below it.
By their numbers in this assay, from the lowest: compound 2; then compound 3; then compounds 1 and 4 (each within the scatter of the next).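

At the nitrogen on an aromatic ring, in this assay, benzyl in place of 4-(pyridin-2-yl)phenyl gives a number 26.6 percentage points higher from compound 3 to compound 4 (beyond the scatter), whereas benzyl in place of phenyl gives a number 2 percentage points higher from compound 1 to compound 4 (within the scatter), so benzyl and phenyl are not told apart here and, of these three groups, only 4-(pyridin-2-yl)phenyl goes with the lower number. With benzyl held on that nitrogen, (2-aminophenyl)carbamoyl in place of 2-((2-aminophenyl)carbamoyl)ethenyl on an aromatic carbon gives a number 40.1 percentage points higher from compound 2 to compound 4 (beyond the scatter), which shows that this second place also strongly affects the read-out. Nothing available here explains either change.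

The compounds shown leave open whether a longer chain such as 2-phenylethyl on that nitrogen would keep the number of compound 4. They also leave open whether pyridin-2-yl on the benzyl would lower it as it did on the phenyl.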